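Amide aryl variation on the shared quinazoline-thioacetamide core

A few compounds are considered here, and "the series" means these few. Any claim that something is new, unique, unknown or untested is made for them only; others in the source may bear on it.

Measured so far in a functional assay on MDA-MB-231 cells (Homo sapiens) for inhibition, read by MTT assay, with a stated time of 72 h; on this read-out lower numbers stand for stronger inhibition and higher numbers for weaker inhibition:
Compound 1 `O=C(CSc1nc(Nc2ccccc2)c2ccccc2n1)Nc1ccccc1F`: > 50000 nM
Compound 2 `COc1cccc(NC(=O)CSc2nc(Nc3ccccc3)c3ccccc3n2)c1`: 21700 nM

Compound 1 reaches only the limit of the limit of > 50000 nM in this assay, at which 1 of the 2 values shown sits, so no number is recorded for it. Within the data shown here, compound 2 therefore holds the only finite value in this assay, with 21700 nM; nothing else in the set can be placed against it as a number. Among the measured compounds shown here, the one measured step, an at least 2.3-fold lower number from compound 1 to compound 2 (0.36 log units; beyond the scatter), is the sole guide, and it is a bound rather than an exact size, since compound 1 sits at the limit.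

Compound 3 `O=C(CSc1nc(Nc2ccccc2)c2ccccc2n1)Nc1ccc(F)cc1` is not yet measured in this assay. Its change from compound 2 is 4-fluorophenyl in place of 3-methoxyphenyl on an amide-type nitrogen. The measured step moved away from a fluorophenyl toward the methoxyphenyl and gave a lower number; the new compound moves back to a fluorophenyl, though not the same one, so a return toward a higher number is the plainer expectation, with a real chance of another limit.

The estimate for compound 3 in this assay is 35000 nM, within 12000 nM to 100000 nM. The step this implies, a 1.6-fold higher number from compound 2 to compound 3 (0.21 log units; within the scatter), is expected to be a modest rise in the number.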

Compound 3, half-maximal inhibitory concentration: 34100 nM
Compound 3: middle estimate off by 1.0-fold (0.01 log units), on the high side, and the stated range covers the measured number.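

The step of a 1.6-fold higher number from compound 2 to compound 3 (0.20 log units; within the scatter) leaves 4-fluorophenyl and 3-methoxyphenyl on the amide-type nitrogen level with each other in this assay, so the methoxy group is not needed for a finite reading in this small set. The comparison between the two fluorophenyl groups, an at least 1.4-fold lower number from compound 1 to compound 3 (0.16 log units; that floor lies within the scatter), has a floor that does not by itself establish a real difference, although compound 3 does give a number. Compound 1 remains a limit rather than a number, so the true size of that step stays unknown: the limit of > 50000 nM in this assay, at which 1 of the 3 values shown sits.

From the compounds shown here alone, whether the 2-fluorophenyl and 4-fluorophenyl groups truly differ therefore stays open, and all that can be said is that only the 4-fluorophenyl compound gives a finite reading. Also open is how the read-out would respond at this nitrogen to an unsubstituted phenyl, a pyridine ring or an aryl group carrying a carboxylic acid or an amine, since the groups shown are only one fluorophenyl pair and one methoxyphenyl.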